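The source may hold more compounds than are shown below. What is called first, only, known or untested is meant among the compounds shown, and "the series" means these compounds.

Among the measured compounds shown here, in a functional assay on the whole organism (strain Wistar) with Rattus norvegicus as the target, with a stated time of 5 min (on this read-out lower numbers stand for an effect already at smaller amounts and higher numbers for an effect only at larger amounts of compound), the three measured compounds give only one plain number. For the measured compounds named here, compound 1 `CCC1(CCCCN2CCN(c3ccc(F)cc3)CC2)C(=O)Nc2ccccc21` is that one case: in this assay compound 1 gives 10 mg/kg, and it therefore stands alone as the single value on which any comparison can rest. Compound 2 `O=C1Nc2ccc(F)cc2C1CCCCN1CCN(c2ccc(F)cc2)CC1` reaches only a limit of the assay, for in this assay compound 2 gives > 10 mg/kg. Compound 3 `CCC1(CCCCN2CCN(c3cccc(Cl)c3)CC2)C(=O)Nc2ccc(Cl)cc21` likewise stops at a limit of the assay, and in this assay compound 3 gives > 20 mg/kg. Going by the values given here, both limits, the limit of > 10 mg/kg in this assay, at which 1 of the 3 values shown sits, and (the limit of > 20 mg/kg in this assay, at which 1 of the 3 values shown sits), leave open where those two compounds would truly fall, so no completed step between measured compounds can be drawn, and nothing beyond the two values themselves should be read into either pair.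

Compound 4 `CCC1(CCCCN2CCN(c3ccc(OC)cc3)CC2)C(=O)Nc2ccccc21` differs from compound 1 in one place, (methoxy in place of fluoro on an aromatic carbon). Among the compounds with values here, with no measured step to lean on, the change from compound 1 to compound 4 is expected to stay within the scatter of repeated runs, so no change at the digits printed from compound 1 to compound 4 (within the scatter) is expected to be small. In this assay compound 4 is accordingly estimated at 10 mg/kg, with a range from 5 mg/kg to 20 mg/kg, bearing in mind that the read-out may again report only a limit.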

Compound 4, minimum effective dose: > 20 mg/kg
Compound 4: a limit, no number (the forecaster's own chance of this, stated with the estimate: 40%); middle value at least 2.0-fold (0.30 log units) away from the limit.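

Among the compounds shown here, the change from 4-fluorophenyl to 4-methoxyphenyl gives the first step between compounds that differ in one place, and in this assay it reads as an at least 2.0-fold higher number from compound 1 to compound 4 (0.30 log units; that floor lies within the scatter). Going by these compounds, compound 4 stops at a limit of the assay and gives no number, so this step has only a floor and its full size stays unknown: the limit of > 20 mg/kg in this assay, at which 2 of the 4 values shown sit. At this position, on an aromatic carbon para to a large group, the read-out no longer gives a plain number once methoxy replaces fluoro, something compound 2 and compound 3 could not show, since neither differs from compound 1 in one place.

The compounds shown leave open how far compound 4 actually lies from compound 1, and whether this one change says anything about the same position in other members of the series. They also leave open what other groups at this place would give, such as a chlorine atom, a hydroxyl, an amine or a longer alkoxy chain, and whether any of these would return a plain number in this assay.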